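The source may hold more compounds than are shown below. What is called first, only, known or untested is meant among the compounds shown, and "the series" means these compounds.

Of the compounds shown here, three that share one core have been measured in a functional assay on SMMC-7721 cells (Homo sapiens) for antiproliferative activity, read by MTT assay, with a stated time of 48 h; a lower number here means a stronger inhibitor, a higher number a weaker inhibitor. Compound 1 `CC(=O)OC/C1=C/C[C@](C)(CCC=C(C)C)/C=C/[C@@H](OC(=O)C=C(C)C)[C@](C)(O)/C=C/C1=O` gives 2950 nM in this assay, which is the second highest of the three numbers: its nearest neighbour is compound 3 `CC(C)=CCC[C@]1(C)/C=C/[C@@H](OC(=O)C=C(C)C)[C@](C)(O)/C=C/C(=O)/C(C(=O)N(C)C)=C\C1` with 3670 nM, and its furthest is compound 2 `CSC(=S)OC/C1=C/C[C@](C)(CCC=C(C)C)/C=C/[C@@H](OC(=O)C=C(C)C)[C@](C)(O)/C=C/C1=O` with 720 nM. The step from compound 1 to compound 2 is a 4.1-fold lower number from compound 1 to compound 2 (0.61 log units; beyond the scatter), whereas the step from compound 1 to compound 3 is a 1.2-fold higher number from compound 1 to compound 3 (0.09 log units; within the scatter), and the step from compound 2 to compound 3 is a 5.1-fold higher number from compound 2 to compound 3 (0.71 log units; beyond the scatter).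

Compound 4 `CCN(CC)C(=O)/C1=C/C[C@](C)(CCC=C(C)C)/C=C/[C@@H](OC(=O)C=C(C)C)[C@](C)(O)/C=C/C1=O` has not yet been measured in this assay. It differs from compound 1 in one place: diethylcarbamoyl in place of acetoxymethyl on a double-bonded ring carbon. Among the compounds with values here, the measured step that bears most directly on this change is the one from compound 1 to compound 3, where a dimethylcarbamoyl group took the place of the same acetoxymethyl group at the same ring carbon and the number moved by a 1.2-fold higher number from compound 1 to compound 3 (0.09 log units; within the scatter). A diethylcarbamoyl group is a close relative of that change, so no step beyond the scatter is expected in either direction; the step from compound 1 to compound 4 is estimated at a 1.1-fold higher number from compound 1 to compound 4 (0.05 log units; within the scatter). Compound 4 is therefore expected to give about 3300 nM in this assay, most likely between 1500 nM and 7500 nM.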

Compound 4, half-maximal inhibitory concentration: 13800 nM
Beside the measured number, compound 4's estimate is 4.2-fold (0.62 log units) below it; measured number outside the range, above it.
By their numbers in this assay, from the lowest: compound 2; then compounds 1 and 3 (each within the scatter of the next); then compound 4.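

At this double-bonded ring carbon, the groups on the carbamoyl nitrogen turn out to matter: diethylamino in place of dimethylamino on the carbonyl carbon gives a 3.8-fold higher number from compound 3 to compound 4 (0.58 log units; beyond the scatter), although the change from acetoxymethyl to dimethylcarbamoyl had stayed within the scatter. A carbamoyl group at this position is therefore not equivalent across its variants in this assay: the diethylcarbamoyl group gives a 4.7-fold higher number from compound 1 to compound 4 (0.67 log units; beyond the scatter), and the comparison with the sulfur-bearing group at the same carbon gives a 19-fold higher number from compound 2 to compound 4 (1.28 log units; beyond the scatter), the largest step in this set. No measurement available here explains why the number shifts with this change.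

From the compounds shown here alone, with only dimethylcarbamoyl and diethylcarbamoyl to compare, it remains open whether the number keeps rising as the chains on the nitrogen lengthen, as a dipropylcarbamoyl group would test, or whether the ethyl groups are a special case. A carbamoyl group with a single ethyl on the nitrogen, or one whose nitrogen is closed into a pyrrolidine ring, would also show whether the size of the group or the number of chains on the nitrogen tracks with this shift.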